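A few compounds are considered here, and "the series" means these few. Any claim that something is new, unique, unknown or untested is made for them only; others in the source may bear on it.

Working notes on the phthalazine-hydrazine series in a functional assay on DU-145 cells (Homo sapiens) for antiproliferative activity, read by sulforhodamine B assay, with a stated time of 72 h; on this read-out higher numbers stand for weaker inhibition and lower numbers for stronger inhibition. Of the compounds shown here, two have numbers so far. Compound 1, `Cc1ccc(C(/C=C/c2ccc(F)cc2)=N\Nc2nncc3ccccc23)cc1`, gives 5.6 nM in this assay. Compound 2, `NC(=S)NNc1nncc2ccccc12`, gives 65 nM in this assay. For the measured compounds named here, of the two numbers, compound 2 stands highest; the only neighbour, compound 1, sits at a lower number, and the gap between them is beyond the scatter. Compound 1 and compound 2 differ in more than one place, so the two values are recorded side by side without any step being read into them.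

The next compound, compound 3, `S=C(NNc1nncc2ccccc12)Nc1ccccc1`, is not yet measured in this assay. Against compound 2 it differs in one place: phenyl in place of hydrogen on an amide-type nitrogen. Going by the values given here, no measured pair in the set shows this kind of change, so nothing in the data fixes its size or direction. The expectation is a modest step toward a lower number, a 2.2-fold lower number from compound 2 to compound 3 (0.34 log units; beyond the scatter), close to the edge of the scatter. Compound 3 is therefore expected to give about 30 nM in this assay, within a range of 8 nM to 120 nM.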

Compound 3, half-maximal inhibitory concentration: 45 nM
The estimate for compound 3 lay 1.5-fold (0.18 log units) below the measured number; measured number inside the range.
By their numbers in this assay, from the lowest: compound 1; then compounds 3 and 2 (each within the scatter of the next).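

Phenyl in place of hydrogen on an amide-type nitrogen whose other neighbour is the thiocarbonyl carbon gives the first single-place step in the series: in this assay the amino to anilino change reads as a 1.4-fold lower number from compound 2 to compound 3 (0.16 log units; within the scatter) and so leaves the two compounds within the scatter of each other. This position therefore accepts a six-membered aromatic ring of six heavy atoms without a shift that the read-out can separate from repeat variation, which a comparison of compound 1 with compound 2 could not show because those two differ in more than one place. Nothing at hand bears on the reason for this result.

The compounds shown leave open whether the same nitrogen would accept a methyl, a benzyl or a longer alkyl chain, and whether a phenyl carrying a fluoro or methoxy group would stay within the scatter of compound 3. They also leave open what a carbonyl in place of the thiocarbonyl would do, and no single-place route yet links compound 1 to the thiocarbonyl compounds.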